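From 2,3-dichlorophenyl to 4-methoxyphenyl on compound 2

A few compounds are considered here, and "the series" means these few. Any claim that something is new, unique, unknown or untested is made for them only; others in the source may bear on it.

Compound 1 `NC1=NC2(CCOCC2)N(OCCCOc2ccc(Cl)cc2)C(N)=N1` gives 690 nM
Compound 2 `NC1=NC2(CCSCC2)N(OCCCOc2cccc(Cl)c2Cl)C(N)=N1` gives 1 nM
Compound 3 `Cc1ccc(OCCCON2C(N)=NC(N)=NC23CCOCC3)cc1` gives 2390 nM

In a functional assay on HCT-116 cells (Homo sapiens) for antiproliferative activity, read by MTT assay, with a stated time of 72 h (on this read-out higher numbers stand for weaker inhibition and lower numbers for stronger inhibition), compound 2 gives 1 nM, the lowest number of the three and well beyond the scatter from both others. Compound 4 `COc1ccc(OCCCON2C(N)=NC(N)=NC23CCSCC3)cc1` is still unmeasured. It differs from compound 2 in one place: 4-methoxyphenyl in place of 2,3-dichlorophenyl on an oxygen on a saturated carbon. Within the data shown here, the only measured step is modest, a 3.5-fold higher number from compound 1 to compound 3 (0.54 log units; beyond the scatter), and it tests no methoxy group, so it bears only loosely. Compound 1 and compound 3 also lack the 2,3-dichlorophenyl group and sit far higher, though their core differs from that of compound 2. A large rise, meaning weaker inhibition, is therefore expected in this assay: the estimated step is a 300-fold higher number from compound 2 to compound 4 (2.48 log units; beyond the scatter). For compound 4 the expected value is 300 nM, with an estimated range of 30 nM to 2500 nM.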

Compound 4, half-maximal inhibitory concentration: 70 nM
Beside the measured number, compound 4's estimate is 4.3-fold (0.63 log units) above it; measured number inside the range.
By their numbers in this assay, from the lowest: compound 2; then compound 4; then compound 1; then compound 3.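

In this assay, replacing 2,3-dichlorophenyl with 4-methoxyphenyl gives a 70-fold higher number from compound 2 to compound 4 (1.85 log units; beyond the scatter), so the aromatic group on this oxygen strongly affects the number on the core of compound 2. The two groups have the same heavy-atom count, so that count alone does not set the number. Nothing measured here explains the rise.

This single swap removes the chlorines and adds the methoxy group together, so their separate contributions remain unresolved. On these data alone, how a plain phenyl, 4-aminophenyl or 4-carboxyphenyl group would behave here also remains open.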